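Hydroxamic acid series: cap variation at the ring nitrogen

The source may hold more compounds than are shown below. What is called first, only, known or untested is meant among the compounds shown, and "the series" means these compounds.

Measured compounds:
compound 1 `O=C(CCC1=CCCN(CCCCc2ccc(-c3ccccc3)cc2)C1=O)NO` — 1280 nM
compound 3 `O=C(CCC1=CCCN(CCCc2ccc(-c3ccccc3)cc2)C1=O)NO` — 1040 nM
compound 2 `CC(=O)Nc1ccc(CN2CCC=C(CCC(=O)NO)C2=O)cc1` — "not determined" (no result reported)

In a functional assay on MDA-MB-231 cells (Homo sapiens) for inhibition, read by sulforhodamine B assay (a lower number here means a stronger inhibitor of growth, a higher number a weaker inhibitor of growth), compound 1 gives 1280 nM and compound 3 gives 1040 nM; these two numbers lie within the scatter of each other, so nothing can be said of an order between them. Compound 2 has no result in this assay, so it stands nowhere on the numbers shown, and no measured step leads from it to any other compound.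

Compound 4 `O=C(CCC1=CCCN(Cc2ccc(NC(=O)c3ccccc3)cc2)C1=O)NO` differs from compound 2 in one place: phenyl in place of methyl on a carbonyl carbon. Within the data shown here, with no number for compound 2, the size and direction of the step in this assay cannot be anchored; the only numbers available are those of compound 1 and compound 3, which share the hydroxamic acid side chain and the core but carry a different cap. On that basis the growth inhibition of compound 4 in this assay is expected to fall near these two, at about 1000 nM, within a range from 250 nM to 4000 nM, with a wide margin given the absence of a direct anchor.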

Compound 4, concentration for 50% growth inhibition: 6030 nM
Compound 4: middle estimate off by 6.0-fold (0.78 log units), on the low side, outside the stated range (above it).
By their numbers in this assay, from the lowest: compounds 3 and 1 (each within the scatter of the next); then compound 4.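

Among these compounds, the values shown give no step from compound 2 to compound 4 in this assay. No evidence on this result is at hand. The compounds shown leave open how far acetyl to benzoyl alone moves growth inhibition in this assay.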